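Working notes: amide-side variation toward compound 4

A few compounds are considered here, and "the series" means these few. Any claim that something is new, unique, unknown or untested is made for them only; others in the source may bear on it.

Measured so far in an assay on LtK cells with ATP-sensitive inward rectifier potassium channel 11 (Homo sapiens) as the target; a higher number here means that more compound is needed for the effect, a lower number that less compound is needed:
compound 1 `CC(C)=CC(=O)Nc1c(C(O)(C(F)(F)F)C(F)(F)F)ccc2ccccc12` gives 46 nM
compound 2 `O=C(CC1CCCC1)Nc1c(C(O)(C(F)(F)F)C(F)(F)F)ccc2ccccc12` gives 81 nM
compound 3 `O=C(Nc1c(C(O)(C(F)(F)F)C(F)(F)F)ccc2ccccc12)c1cccc(Br)c1` gives 80 nM

Compound 3 stands second highest of the three numbers, yet every gap to it lies within the scatter: a 1.0-fold lower number from compound 2 to compound 3 (0.01 log units; within the scatter) and a 1.7-fold higher number from compound 1 to compound 3 (0.24 log units; within the scatter). The third measured step, a 1.8-fold higher number from compound 1 to compound 2 (0.25 log units; within the scatter), is likewise within the scatter. Across the three exchanges on the carbonyl carbon, the read-out has not moved beyond repeat variation.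

Compound 4 `O=C(Nc1c(C(O)(C(F)(F)F)C(F)(F)F)ccc2ccccc12)c1ccco1` continues the same series. The change is furan-2-yl in place of 3-bromophenyl on a carbonyl carbon. For the measured compounds named here, no measured step involves furan-2-yl, so the expectation rests only on the three carbonyl-carbon exchanges above, all of them within the scatter. The step from compound 3 to compound 4 is therefore expected to be small, with no direction claimed: a 1.1-fold higher number from compound 3 to compound 4 (0.05 log units; within the scatter). For compound 4 the estimate in this assay is 90 nM, with a range from 35 nM to 250 nM.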

Compound 4, half-maximal effective concentration: 9 nM
Compound 4: the middle estimate sits 10-fold (1.00 log units) above what was measured; measured number below the stated range.
By their numbers in this assay, from the lowest: compound 4; then compounds 1, 3 and 2 (each within the scatter of the next).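

The carbonyl-carbon position is not flat in this assay: an 8.9-fold lower number from compound 3 to compound 4 (0.95 log units; beyond the scatter), a 9.0-fold lower number from compound 2 to compound 4 (0.95 log units; beyond the scatter) and a 5.1-fold lower number from compound 1 to compound 4 (0.71 log units; beyond the scatter), all beyond the scatter, whereas exchanges among 2-methylprop-1-en-1-yl, cyclopentylmethyl and 3-bromophenyl stayed within it. Relative to 3-bromophenyl, furan-2-yl changes several things at once: a five-membered aromatic ring with 1 hetero atom replaces a six-membered carbon ring, the bromine leaves, and 1 hydrogen-bond acceptor enters. Nothing available identifies which of these differences accounts for the step.

Still open, from the compounds shown here alone, is how these differences separate: unsubstituted phenyl would remove only the bromine from compound 3, while thiophen-2-yl would keep the five-membered ring with sulfur in place of the ring oxygen. Also open, going by these compounds, is whether furan-3-yl, with the same ring attached differently, gives a similar number.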